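The source may hold more compounds than are shown below. What is called first, only, known or untested is meant among the compounds shown, and "the series" means these compounds.

Within the data shown here, compound 2 `COc1ccc([C@@H]2C/C(=N/OCc3cn(-c4cccc(CO)c4)nn3)c3cc(CC=C(C)C)c(OC)cc3O2)cc1` stands lowest of the three measured members in a functional assay on HCT-116 cells (Homo sapiens) for inhibition, read by sulforhodamine B assay, with a stated time of 48 h, tested at 50 uM; a lower number here means less inhibition of growth, a higher number more inhibition of growth at the concentration tested: compound 2 gives 27%. Its nearest neighbour is compound 3 `COc1ccc([C@@H]2CC(=O)c3cc(CC=C(C)C)c(OC)cc3O2)cc1`, which in this assay gives 68%, a gap beyond the usual scatter. Furthest away is compound 1 `COc1cc2c(cc1CC=C(C)C)C(=O)C[C@@H](c1ccc(Oc3ccccc3)cc1)O2`, which in this assay gives 76%, again beyond the scatter.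

Compound 4 `COc1ccc([C@@H]2C/C(=N/OCc3cn(-c4cccnc4Cl)nn3)c3cc(CC=C(C)C)c(OC)cc3O2)cc1` is the next member, differing from compound 2 in one place: 2-chloropyridin-3-yl in place of 3-(hydroxymethyl)phenyl on an aromatic nitrogen. The entering group sits on an aromatic nitrogen of the five-membered aromatic ring with 3 nitrogen; the leaving 3-(hydroxymethyl)phenyl takes its one hydrogen-bond donor with it, and the entering 2-chloropyridin-3-yl brings one hydrogen-bond acceptor and no donor.

Among the measured compounds shown here, the only measured step, a number 8 percentage points lower from compound 1 to compound 3 (within the scatter), concerns methyl in place of phenyl on an oxygen on an aromatic ring elsewhere in the molecule and is within the scatter; it does not touch the group on the aromatic nitrogen and says nothing direct about this change. For the measured compounds named here, no measured pair varies that group at all. The expectation in this assay is therefore no step beyond the scatter, and the estimated step is a number 1 percentage points higher from compound 2 to compound 4 (within the scatter). Compound 4 is expected to give 28% in this assay, with a range from 12% to 45%.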

Compound 4, percent growth inhibition at one concentration: 47%
Compound 4: the middle estimate sits 19 percentage points below what was measured; the whole stated range lies below it.
By their numbers in this assay, from the lowest: compound 2; then compound 4; then compounds 3 and 1 (each within the scatter of the next).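

The group on the aromatic nitrogen of the five-membered aromatic ring with 3 nitrogen is not silent in this assay: 2-chloropyridin-3-yl in place of 3-(hydroxymethyl)phenyl gives a number 20 percentage points higher from compound 2 to compound 4 (beyond the scatter). Among these compounds, this is the only step among the measured compounds that varies this position, and unlike the change on the oxygen on the aromatic ring, it lies beyond the scatter. The exchange removes the hydrogen-bond donor and brings in a ring nitrogen and a chlorine in one move, and no measurement on hand accounts for the step or assigns it to any one of these changes.

Open, as far as these compounds go, is which part of the exchange carries the step: an unsubstituted phenyl or a pyridin-3-yl without the chlorine on the same aromatic nitrogen would separate the loss of the hydroxymethyl from the entry of the ring nitrogen and the chlorine. Also open, from the compounds shown here alone, is whether the same exchange gives a step of this size with phenyl in place of methyl on the oxygen on the aromatic ring.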